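This account rests on a few compounds, and the source may have more. Where it says the series, first, only, none or still open, it means among the compounds named here.

Four compounds sharing one core were examined in a functional assay on KB cells (Homo sapiens) for antiproliferative activity, read by sulforhodamine B assay, with a stated time of 3 days; on this read-out lower numbers stand for an effect already at smaller amounts and higher numbers for an effect only at larger amounts of compound: compound 1 (`CCC1=C(O)c2c(oc(-c3ccc(F)cc3)cc2=O)C(CC)(CC)C1=O`), compound 2 (`CCC1=C(O)c2c(oc(-c3ccc(CBr)cc3)cc2=O)C(CC)(CC)C1=O`), compound 3 (`CCC1=C(O)c2c(oc(-c3cc(C)c(O)c(C)c3)cc2=O)C(CC)(CC)C1=O`) and the still unmeasured compound 4 (`CCC1=C(O)c2c(oc(-c3cc(C)ccc3F)cc2=O)C(CC)(CC)C1=O`). In this assay compound 1 gives 33 uM and compound 3 gives 18.3 uM, and a 1.8-fold lower number from compound 1 to compound 3 (0.26 log units; within the scatter) places the two within the scatter of each other. Compound 2 is reported only as a limit, > 46.5 uM. Compound 3 stands apart from that limit, since an at least 2.5-fold lower number from compound 2 to compound 3 (0.40 log units; beyond the scatter) is a modest step beyond the scatter, whereas an at least 1.4-fold higher number from compound 1 to compound 2 (0.14 log units; that floor lies within the scatter) has a floor within it.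

In compound 4, the 4-hydroxy-3,5-dimethylphenyl on the aromatic carbon next to the ring oxygen gives way to 2-fluoro-5-methylphenyl (2-fluoro-5-methylphenyl in place of 4-hydroxy-3,5-dimethylphenyl on an aromatic carbon). The nearest measured precedent is the exchange between 4-fluorophenyl and 4-hydroxy-3,5-dimethylphenyl, a 1.8-fold lower number from compound 1 to compound 3 (0.26 log units; within the scatter), because compound 1, like compound 4, carries a fluoro group and no hydroxy group. The bromomethyl compound bears on the change less directly. A small move toward a higher number in this assay is therefore expected, and nothing beyond the scatter, with the estimated change being a 1.5-fold higher number from compound 3 to compound 4 (0.18 log units; within the scatter). The expected value for compound 4 is 28 uM, with an estimated range from 13 uM to 60 uM.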

Compound 4, concentration for half-maximal effect: 47.3 uM
Estimate against measurement, compound 4: 1.7-fold (0.23 log units) below; the range from low to high includes it.
By their numbers in this assay, from the lowest: compounds 3, 1 and 4 (each within the scatter of the next, the first and the last beyond it).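

In this assay, among these compounds, the exchange of 4-hydroxy-3,5-dimethylphenyl for 2-fluoro-5-methylphenyl on the aromatic carbon next to the ring oxygen gives a 2.6-fold higher number from compound 3 to compound 4 (0.41 log units; beyond the scatter), the first step at this position between two exact values that passes the scatter, though only modestly. Against 4-fluorophenyl the same group gives a 1.4-fold higher number from compound 1 to compound 4 (0.16 log units; within the scatter), so the two fluoro-bearing aryl groups of compound 1 and compound 4 are not told apart here, and the hydroxy-bearing aryl group of compound 3 separates only from compound 4, not from compound 1. The step between compound 2 and compound 4 cannot be read, because compound 2 is reported only as a limit: the limit of > 46.5 uM in this assay, at which 1 of the 4 values shown sits.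

The exchange from compound 3 to compound 4 alters the hydroxy group, the methyl groups and the fluoro group together, so the compounds shown do not say which of these carries the step. On these data alone, it also stays open whether an amine or a carboxylic acid in place of that hydroxy group on the 4-hydroxy-3,5-dimethylphenyl would move the number in either direction.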